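A few compounds are considered here, and "the series" means these few. Any claim that something is new, unique, unknown or untested is made for them only; others in the source may bear on it.

Three compounds share one core and differ only in the group carried on an aromatic carbon. Compound 1 `Cc1ccc2nc(N(C)C)nc(NCc3ccc(C(=O)NC4CCN(Cc5ccc(F)cc5)CC4)cc3)c2c1` gives 1100 nM in a functional assay on SW480 cells (Homo sapiens) for inhibition, read by luminescence and resazurin assay, with a stated time of 3 days; on this read-out lower numbers stand for stronger inhibition and higher numbers for weaker inhibition. Compound 2 `Cc1ccc2nc(N3CCNC(C)C3)nc(NCc3ccc(C(=O)NC4CCN(Cc5ccc(F)cc5)CC4)cc3)c2c1` gives 1000 nM in this assay, and compound 3 `CCCNc1nc(NCc2ccc(C(=O)NC3CCN(Cc4ccc(F)cc4)CC3)cc2)c2cc(C)ccc2n1` gives 1100 nM in this assay. The steps among them are small: a 1.1-fold lower number from compound 1 to compound 2 (0.04 log units; within the scatter), no change at the digits printed from compound 1 to compound 3 (within the scatter) and a 1.1-fold higher number from compound 2 to compound 3 (0.04 log units; within the scatter). Compound 3 thus sits level with compound 1, the two of them holding the highest numbers of the three, though none of the three numbers can be told apart from the others.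

Compound 4 `CCCNc1nc(NCc2ccc(C(=O)NC3CCN(C(=O)c4ccc(F)cc4)CC3)cc2)c2cc(C)ccc2n1` departs from compound 3 at a different place: (4-fluorophenyl)carbonyl in place of 4-fluorobenzyl on an amine nitrogen in a ring. Going by the values given here, none of the measured steps touches this amine nitrogen in a ring; all three concern the group on the aromatic carbon, so no measured step bears on the size or the direction of this change. Among the compounds with values here, the only guide is that the three measured compounds cluster together, which says nothing about a change made elsewhere in the molecule. The expected value for compound 4 in this assay is therefore set close to compound 3 with a wide range, at 1500 nM, between 400 nM and 6000 nM. This estimate means the step of a 1.4-fold higher number from compound 3 to compound 4 (0.13 log units; within the scatter) is expected to be small, with its direction unknown.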

Compound 4, half-maximal inhibitory concentration: 5500 nM
For compound 4 the middle estimate is 3.7-fold (0.56 log units) below the measured one; measured number inside the range.
By their numbers in this assay, from the lowest: compounds 2, 1 and 3 (each within the scatter of the next); then compound 4.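

Going by these compounds alone, until now, the only changes were to the group on the aromatic carbon, and compounds 1, 2 and 3 could not be told apart. The change on the amine nitrogen in a ring gives a 5.0-fold higher number from compound 3 to compound 4 (0.70 log units; beyond the scatter) in this assay and lies beyond the scatter, so this position, unlike the aromatic carbon so far, does affect the result. Replacing 4-fluorobenzyl with (4-fluorophenyl)carbonyl keeps the fluorinated aromatic ring and adds a carbonyl, and here that swap goes with weaker inhibition, although nothing available explains the shift.

Among the compounds shown, this nitrogen carries only these two groups, so it remains open whether a small group such as methyl, a sulfonyl link to the same ring or a longer chain such as 2-(4-fluorophenyl)ethyl would stay close to compound 3 or move further from it. Going by these compounds, it is also open whether the carbonyl would have a similar effect with dimethylamino or 3-methylpiperazin-1-yl on the aromatic carbon, as it appears here only with propylamino.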